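Methoxy placement on the aroyl ester in a cinnamate series

The compounds below may be only part of what the source reports. "The series", "measured", "known", "first", "only" and "open" are said of these compounds alone.

Measured so far in a functional assay on HL-60 cells (Homo sapiens) for cytotoxicity, read by MTT assay, with a stated time of 24 h; on this read-out lower numbers stand for stronger inhibition and higher numbers for weaker inhibition:
compound 1, `COC(=O)/C(=C\c1ccc(OC(=O)c2cccc(OC)c2)cc1)Sc1ccnc2cc(Cl)ccc12`, 25500 nM
compound 2, `COC(=O)/C(=C\c1ccc(OC(=O)c2cc(OC)cc(OC)c2OC)cc1)Sc1ccnc2cc(Cl)ccc12`, 10700 nM

Compound 2 holds the lowest of the two numbers in this assay; its nearest neighbour is compound 1, with a 2.4-fold lower number from compound 1 to compound 2 (0.38 log units; beyond the scatter), a modest step that comes from exchanging the aroyl group on the carbonyl carbon. Compound 3, `COC(=O)/C(=C\c1ccc(OC(=O)c2ccc(OC)c(OC)c2OC)cc1)Sc1ccnc2cc(Cl)ccc12`, keeps every atom of compound 2 and only rearranges them: 2,3,4-trimethoxyphenyl in place of 2,3,5-trimethoxyphenyl on a carbonyl carbon. Going by the values given here, no measured pair in the set compares two trimethoxyphenyl isomers, so the step from compound 1 to compound 2 is the only guide, and it speaks to adding methoxy groups, not to moving one of them. With three methoxy groups retained, no step beyond the scatter is expected in this assay. Compound 3 is therefore expected near 12000 nM, between 5000 nM and 30000 nM, which means an expected step of a 1.1-fold higher number from compound 2 to compound 3 (0.05 log units; within the scatter).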

Compound 3, half-maximal inhibitory concentration: 2080 nM
Compound 3: middle estimate off by 5.8-fold (0.76 log units), on the high side; measured number outside the range, below it.
By their numbers in this assay, from the lowest: compound 3; then compound 2; then compound 1.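

In this assay, the aroyl group on the carbonyl carbon responds to the arrangement of its methoxy groups and not only to their presence: with the same atoms rearranged, 2,3,4-trimethoxyphenyl in place of 2,3,5-trimethoxyphenyl gives a 5.1-fold lower number from compound 2 to compound 3 (0.71 log units; beyond the scatter) in this series. Against the single-methoxy group, the same 2,3,4-trimethoxyphenyl group gives a 12-fold lower number from compound 1 to compound 3 (1.09 log units; beyond the scatter) and thus a large step, where 2,3,5-trimethoxyphenyl gave only a modest one. No measurement at hand accounts for the difference between the two isomers.

On these data alone, whether a hydroxy group or an amine on the same ring would keep the number of compound 3 remains open. Also open, as far as these compounds go, is whether the order of the three compounds holds in other cell lines or at other exposure times.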